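Amide to urea on the aryl sulfonate series

A few compounds are considered here, and "the series" means these few. Any claim that something is new, unique, unknown or untested is made for them only; others in the source may bear on it.

Two members of a sulfonate ester series have been measured in a functional assay on M21 cells (Homo sapiens) for antiproliferative activity, read by sulforhodamine B assay, with a stated time of 48 h; on this read-out lower numbers stand for stronger inhibition and higher numbers for weaker inhibition. Compound 1 `CCCCCC(=O)Nc1ccc(S(=O)(=O)Oc2ccccc2C(C)C)cc1` gives 6700 nM, the higher of the two numbers; compound 2 `CCCNC(=O)Nc1ccc(S(=O)(=O)Oc2ccccc2I)cc1` gives 5400 nM, which lies within the usual scatter of the number for compound 1, so the two cannot be ordered. Compound 2 differs from compound 1 in more than one place, so no single step can be read from it.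

The step of interest leads to compound 3 `CCCCCNC(=O)Nc1ccc(S(=O)(=O)Oc2ccccc2C(C)C)cc1`, which differs from compound 1 by pentylamino in place of pentyl on a carbonyl carbon. Among the compounds with values here, no pair measured so far isolates this change. With compound 2, a urea, sitting within the scatter of compound 1, an amide, the data give no ground for a large shift in either direction, and the step from compound 1 to compound 3 is expected to stay close to the scatter, a 1.3-fold lower number from compound 1 to compound 3 (0.13 log units; within the scatter). Compound 3 is therefore estimated at 5000 nM, with a range from 1500 nM to 16000 nM.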

Compound 3, half-maximal inhibitory concentration: 4600 nM
For compound 3 the middle estimate is 1.1-fold (0.04 log units) above the measured one; the measured number falls inside the stated range.
By their numbers in this assay, from the lowest: compounds 3, 2 and 1 (each within the scatter of the next).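

Within the data shown here, the pair of compound 1 and compound 3 is the first to isolate pentylamino in place of pentyl on a carbonyl carbon, and in this assay it reads as a 1.5-fold lower number from compound 1 to compound 3 (0.16 log units; within the scatter). At this position on the shared core, with the chain length held, the amide and the urea therefore cannot be told apart, and the one hydrogen-bond donor that pentylamino adds brings no shift that can be read here. No measurement at hand bears on what lies behind this result.

What the compounds shown leave open is whether the same holds for a longer chain such as octylamino or for a cyclic amine such as piperidine on the carbonyl carbon. Pentyloxy in the same place, which would give a carbamate, also remains untested among them.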